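Replacing a Bromine with a Methoxyphenyl Ring

The compounds below may be only part of what the source reports. "The series", "measured", "known", "first", "only" and "open" are said of these compounds alone.

Of the compounds shown here, three have so far been measured in an assay on isolated protein for inhibition of N-acylethanolamine-hydrolyzing acid amidase (Homo sapiens), read by fluorescence, with a stated time of 90 min; a higher number here means a weaker inhibitor, a lower number a stronger inhibitor. Compound 1 `N#CN1CC(OCc2ccc(-c3ccc(C(F)(F)F)cc3)cc2)C1` gives 1.6 nM. Compound 2 `N#CN1CC(OCc2ccc(Oc3ccccc3)cc2)C1` gives 1.1 nM. Compound 3 `N#CN1CC(OCc2ccc(Oc3ccccc3)cc2Br)C1` gives 1.03 nM. On these numbers compound 3 has the lowest value of the three, but its distances to compound 2 and to compound 1 both lie within the usual scatter of repeated measurements, so the three cannot really be told apart. Within the data shown here, the only step in which two measured compounds differ in a single place is a 1.1-fold lower number from compound 2 to compound 3 (0.03 log units; within the scatter), and it shows that putting a bromine in place of a hydrogen on the aromatic ring left the result essentially where it was.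

Compound 4 `COc1ccc(-c2cc(Oc3ccccc3)ccc2COC2CN(C#N)C2)cc1` has not been measured yet. Compared with compound 3, (4-methoxyphenyl in place of bromo on an aromatic carbon). Among the measured compounds shown here, no measured step swaps a bromine for a larger ring, so the only guide is the hydrogen-to-bromine step at this same position, which stayed within the scatter; compound 1 and compound 2 differ in more than one place and simply show two similar values. The step is therefore expected to be modest, a 1.9-fold higher number from compound 3 to compound 4 (0.29 log units; within the scatter), leaning toward a somewhat higher number without certainty of exceeding the scatter. Compound 4 is expected to give 2 nM, within a range from 0.7 nM to 6 nM.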

Compound 4, half-maximal inhibitory concentration: 5.7 nM
Estimate against measurement, compound 4: 2.9-fold (0.45 log units) below; the measured number falls inside the stated range.
By their numbers in this assay, from the lowest: compounds 3, 2 and 1 (each within the scatter of the next); then compound 4.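

This position is not indifferent to what is placed on it. The earlier hydrogen-to-bromine step suggested little response, but in this assay 4-methoxyphenyl in place of bromo gives a 5.5-fold higher number from compound 3 to compound 4 (0.74 log units; beyond the scatter) and marks a real, though modest, change. Measured against the plain hydrogen, the same group gives a 5.2-fold higher number from compound 2 to compound 4 (0.71 log units; beyond the scatter) as a step of similar size, so the conclusion does not depend on which of the two smaller substituents serves as the reference point. Even with a larger substituent of 8 heavy atoms and an added aromatic ring on this carbon, ortho to a group of 8 heavy atoms and meta to a phenoxy group, compound 4 still gives 5.7 nM and so remains a nanomolar inhibitor.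

No supporting measurement is available to explain this rise in the number. The compounds shown leave open whether the step comes from the added ring or from its methoxy group, and how a plain phenyl ring, a 4-hydroxyphenyl ring or a small amine such as dimethylamino would read at this same position.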